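The compounds below may be only part of what the source reports. "The series", "measured", "known", "first", "only" and "open" are said of these compounds alone.

Measured in a functional assay on MGC-803 cells (Homo sapiens) for cytotoxicity, read by MTT assay, with a stated time of 72 h; a higher number here means a weaker inhibitor, a lower number a stronger inhibitor:
Compound 1, `O=C(CSC(=S)N[C@H]1CCOC1=O)Nc1ccccc1F`, gives 122000 nM.
Compound 2, `O=C(CSC(=S)N[C@H]1CCOC1=O)Nc1ccc(Br)cc1`, gives 42800 nM.
Compound 3, `O=C(CSC(=S)N[C@H]1CCOC1=O)Nc1cccc(Cl)c1`, gives 21800 nM.

Compound 2 stands second highest of these three numbers; its gap to compound 3, a 2.0-fold lower number from compound 2 to compound 3 (0.29 log units; within the scatter), lies within the scatter, while a 2.9-fold lower number from compound 1 to compound 2 (0.45 log units; beyond the scatter) lies beyond it. Compound 4, `CCOC(=O)c1ccc(NC(=O)CSC(=S)N[C@H]2CCOC2=O)cc1`, differs from compound 2 at one place: ethoxycarbonyl in place of bromo on an aromatic carbon. The measured steps, a 2.9-fold lower number from compound 1 to compound 2 (0.45 log units; beyond the scatter), a 5.6-fold lower number from compound 1 to compound 3 (0.75 log units; beyond the scatter) and a 2.0-fold lower number from compound 2 to compound 3 (0.29 log units; within the scatter), each exchange one substituted phenyl for another on the amide-type nitrogen; none introduces an ethoxycarbonyl, so none bears directly on this change. No step beyond the scatter in this assay is therefore expected, though with wide uncertainty. Compound 4 is expected to give 40000 nM (range 14000 nM to 120000 nM), which is expected to be a 1.1-fold lower number from compound 2 to compound 4 (0.03 log units; within the scatter).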

Compound 4, half-maximal inhibitory concentration: 21700 nM
The estimate for compound 4 lay 1.8-fold (0.27 log units) above the measured number; the measured number falls inside the stated range.
By their numbers in this assay, from the lowest: compounds 4, 3 and 2 (each within the scatter of the next); then compound 1.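

In this assay, a 2.0-fold lower number from compound 2 to compound 4 (0.29 log units; within the scatter) stays within the scatter, so the two compounds cannot be told apart. The earlier compounds shown here exchanged only one halogen-bearing phenyl for another; here ethoxycarbonyl, with 5 heavy atoms and 2 hydrogen-bond acceptors, replaces bromo on an aromatic carbon para to a large group, with no step beyond the scatter. No evidence on a cause is available for this result. On these data alone, whether an amine, a carboxylic acid or a longer ester chain on this carbon would also stay within the scatter of compound 2 remains open. So does whether ethoxycarbonyl would give the same result elsewhere on the phenyl ring.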